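Dimethylamino to methoxy: cytotoxicity outlook for compound 3

A few compounds are considered here, and "the series" means these few. Any claim that something is new, unique, unknown or untested is made for them only; others in the source may bear on it.

Compound 2 `CN(C)c1ccc(/C=N/NC(=N)NO)cc1` stands at a limit in an ADME assay on Vero cells (Chlorocebus sabaeus) for cytotoxicity; on this read-out lower numbers stand for higher toxicity in this test and higher numbers for lower toxicity in this test: compound 2 gives > 100000 nM, which is a limit of the assay and not a number. Compound 1 `N=C(NO)N/N=C/c1ccc(Cl)cc1` also sits at a limit; in this assay compound 1 gives > 100000 nM, again a limit. Among the measured compounds shown here, the only measured step, a step that the two limits leave unreadable from compound 1 to compound 2, is therefore of unreadable size, both values sharing (the limit of > 100000 nM in this assay, at which 2 of the 2 values shown sit).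

Compound 3 `COc1ccc(/C=N/NC(=N)NO)cc1` differs from compound 2 by methoxy in place of dimethylamino on an aromatic carbon. For the measured compounds named here, the sole step that bears on this change gives no readable size, so no step beyond the scatter is expected in this assay, and a further value at the limit is the most likely outcome. Compound 3 is accordingly estimated at 100000 nM with a range from 30000 nM to 300000 nM. The expected step is a number no higher from compound 2 to compound 3 (the limit leaves the size open), which means no change beyond the scatter.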

Compound 3, half-maximal cytotoxic concentration: > 100000 nM
Compound 3: no number, only a limit; the forecaster's own chance of this, stated with the estimate: 85%; the middle value sits exactly at the limit.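

No step can be read among compound 1, compound 2 and compound 3 in this assay, since each gives only a limit: the limit of > 100000 nM in this assay, at which 3 of the 3 values shown sit.

Going by these compounds, whether chloro, dimethylamino and methoxy on the aromatic carbon differ at all in this assay stays open.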